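Aryl Group Exchange on a Ring Nitrogen: Expected Potency

A few compounds are considered here, and "the series" means these few. Any claim that something is new, unique, unknown or untested is made for them only; others in the source may bear on it.

Compound 1 `N#CC1=C(N)Oc2c(c3nc4ccccc4nc3c3ccccc23)C12C(=O)N(Cc1cnnn1-c1ccc(Br)cc1)c1ccccc12` gives only a limit, > 50000 nM, in a functional assay on HCT-116 cells (Homo sapiens) for antiproliferative activity, read by MTT assay, with a stated time of 48 h; on this read-out lower numbers stand for stronger inhibition and higher numbers for weaker inhibition.
Compound 2 `Cc1cc(C)cc(-n2nncc2CN2C(=O)C3(C(C#N)=C(N)Oc4c3c3nc5ccccc5nc3c3ccccc43)c3ccccc32)c1` likewise gives a limit, > 50000 nM, in this assay.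
Compound 3 `CC(=O)Nc1ccc(-n2nncc2CN2C(=O)C3(C(C#N)=C(N)Oc4c(N)cc5nc6ccccc6nc5c43)c3ccccc32)cc1` also gives a limit, > 50000 nM, in this assay.

All three measured compounds sit at the limit of > 50000 nM in this assay, at which 3 of the 3 values shown sit, so compound 3 stands nowhere distinguishable from its two companions, and no numbered value exists for it. For the measured compounds named here, the one step between measured compounds, a step that the two limits leave unreadable from compound 1 to compound 2, cannot be read. Compound 4 `Cc1ccc(-n2nncc2CN2C(=O)C3(C(C#N)=C(N)Oc4c(N)cc5nc6ccccc6nc5c43)c3ccccc32)cc1Cl` differs from compound 3 in 3-chloro-4-methylphenyl in place of 4-acetamidophenyl on an aromatic nitrogen. Going by the values given here, no measured step touches this particular change, and the single measured step concerns another group on the same kind of nitrogen and gives no size at all. With every value a limit, the expectation for compound 4 is that it too stays at the limit in this assay, meaning a number no higher from compound 3 to compound 4 (the limit leaves the size open), which is no readable step. Compound 4 is estimated at 50000 nM, within 20000 nM to 100000 nM, with a limit rather than a number the most probable report.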

Compound 4, half-maximal inhibitory concentration: > 50000 nM
Compound 4: a limit, no number; the forecaster's own chance of this, stated with the estimate: 85%; the middle value sits exactly at the limit.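

No step can be read from compound 3 to compound 4, since both give only a limit in this assay: the limit of > 50000 nM in this assay, at which 4 of the 4 values shown sit. The compounds shown leave open how strongly any of them inhibits, and whether exchanging the aryl group on the aromatic nitrogen changes that inhibition at all.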